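The source may hold more compounds than are shown below. What is called first, only, known or untested is meant among the compounds shown, and "the series" means these compounds.

Three measured compounds share one core and differ only at its outer positions: compound 1 is `CC(=O)c1cccc(-c2ccc(C(=O)N(Cc3cccc(OCCCCCC(=O)O)c3)C(C)C)cc2)c1`, compound 2 is `CCOc1cccc(-c2ccc(C(=O)N(Cc3cccc(OCCCCCC(=O)O)c3)C(C)C)cc2)c1` and compound 3 is `CCOC(=O)CCCCCOc1cccc(CN(C(=O)c2ccc(-c3cccc(C(C)=O)c3)cc2)C(C)C)c1`. In an ADME assay on BJ cells (Homo sapiens) for cytotoxicity, read by CellTiter-Glo and resazurin assay, with a stated time of 72 h (on this read-out higher numbers stand for an effect only at larger amounts of compound and lower numbers for an effect already at smaller amounts), compound 1 gives > 26000 nM, which is a limit of the assay and not a number. In this assay compound 2 gives > 20800 nM, again a limit. In this assay compound 3 gives > 26000 nM, also a limit. Compound 3 thus stands at the limit of > 26000 nM in this assay, at which 2 of the 3 values shown sit, and every value in the set is a limit, either the limit of > 20800 nM in this assay, at which 1 of the 3 values shown sits, or (the limit of > 26000 nM in this assay, at which 2 of the 3 values shown sit). For that reason the steps a step that the two limits leave unreadable from compound 1 to compound 2 and a step that the two limits leave unreadable from compound 1 to compound 3 cannot be read in size or direction.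

Compound 4 is `CCOC(=O)CCCCCOc1cccc(CN(C(=O)c2ccc(-c3cccc(Br)c3)cc2)C(C)C)c1`. Against compound 3 the change is bromo in place of acetyl on an aromatic carbon. Within the data shown here, no measured step touches the acetyl on that ring, so no step bears directly on this change; what the set shows is only that all three measured compounds sit at a limit in this assay. The expectation for compound 4 is therefore no step beyond the scatter in this assay, and the estimated step is a step that the limit leaves unreadable from compound 3 to compound 4. Compound 4 is estimated at 30000 nM in this assay, within a range of 15000 nM to 60000 nM, most probably reported again as a limit.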

Compound 4, half-maximal effective concentration: > 26000 nM
Compound 4: only a limit was reported (the forecaster's own chance of this, stated with the estimate: 80%); the middle value lies beyond the limit too.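

Compound 3 and compound 4 both sit at a limit in this assay, so the step between them cannot be read in size or direction, and the set stays without a readable step: the limit of > 26000 nM in this assay, at which 3 of the 4 values shown sit.

The compounds shown leave open at what concentration compound 1, compound 2, compound 3 or compound 4 would reach a half-maximal effect in this assay.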